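Three inactive analogues and an untested bromophenyl variant

The source may hold more compounds than are shown below. What is called first, only, known or untested is meant among the compounds shown, and "the series" means these compounds.

Compound 1 `NCCn1ncc2c(NCc3ccccc3[N+](=O)[O-])cc(C(F)(F)F)cc21`: in an assay for inhibition of Indoleamine 2,3-dioxygenase 1 (Homo sapiens), with stated times of 10 min and 60 min (a higher number here means a weaker inhibitor, a lower number a stronger inhibitor), compound 1 gives > 100000 nM, a limit.
Compound 2 `O=C(O)CNc1cccc(CNc2cc(C(F)(F)F)cc3[nH]ncc23)c1`: in this assay compound 2 gives > 100000 nM, a limit.
Compound 3 `FC(F)(F)c1cc(NCC2CNC2)c2cn[nH]c2c1`: in this assay compound 3 gives > 100000 nM, a limit.

Compound 3 therefore stands at no number at all; its value is one of the limits of this assay, and the same holds for the other two compounds shown, so that the limit of > 100000 nM in this assay, at which 3 of the 3 values shown sit, is the only evidence available. Nothing in these results ranks any of the three.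

Compound 4 `FC(F)(F)c1cc(NCc2cccc(Br)c2)c2cn[nH]c2c1` differs from compound 3 in one place: 3-bromophenyl in place of azetidin-3-yl on a saturated chain carbon bound to a nitrogen on an aromatic ring. For the measured compounds named here, no measured step between any pair of compounds exists, so the size and direction of the change cannot be read from the data. On that basis compound 4 is expected to remain weak, with an estimated step from compound 3 of an at least 1.6-fold lower number from compound 3 to compound 4 (0.22 log units; that floor lies within the scatter) and an expected value of 60000 nM, ranging from 8000 nM to 300000 nM.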

Compound 4, half-maximal inhibitory concentration: > 100000 nM
Compound 4: no number, only a limit; the forecaster's own chance of this, stated with the estimate: 65%; at least 1.6-fold (0.22 log units) between middle value and limit.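

In this assay, for the compounds shown here, compound 4 gives > 100000 nM as a limit, so no step from compound 2 or compound 3 to compound 4 can be read. The compounds shown leave open which change to the shared core, if any, would give a measurable value.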